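Swapping a Pyrimidine for a Pyridine on the Amine

A few compounds are considered here, and "the series" means these few. Any claim that something is new, unique, unknown or untested is made for them only; others in the source may bear on it.

Three compounds share a core and were tested in a functional assay on HEK293 cells for antagonist activity at Orexin receptor type 2 (Homo sapiens), read by FLIPR and calcium flux; on this read-out lower numbers stand for lower potency and higher numbers for higher potency (the scale is a negative logarithm). Compound 1 `Cc1nc(C(=O)N2CC3(CC3)C[C@H]2CNc2ncc(Cl)cn2)c(-c2ccccc2)s1` gives 6.8 in this assay, the lowest of the three numbers. Compound 2 `CS(=O)(=O)c1ccc(-c2ccccc2)c(C(=O)N2CC3(CC3)C[C@H]2CNc2ccc(C(F)(F)F)cn2)c1` gives 7.1, which lies within the usual scatter of compound 1, so the two cannot be told apart. Compound 3 `Cc1ccc(-c2nccs2)c(C(=O)N2CC3(CC3)C[C@H]2CNc2ccc(C(F)(F)F)cn2)n1` gives 8, and this sits clearly beyond the scatter above compound 1. None of these three pairs differs in just one place, so no single step can be read from them.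

Compound 4 `Cc1nc(C(=O)N2CC3(CC3)C[C@H]2CNc2ccc(Cl)cn2)c(-c2ccccc2)s1` has not yet been measured in this assay. It differs from compound 1 in one place: 5-chloropyridin-2-yl in place of 5-chloropyrimidin-2-yl on an amine nitrogen. The group that leaves and the group that enters have the same count of heavy atoms and both carry a chlorine; the ring that enters holds one hetero atom where the old one held two, and one hydrogen-bond acceptor where the old one held two.

For the measured compounds named here, with no matching step among the measured compounds, the direction rests on the closeness of the two groups. The step from compound 1 to compound 4 is expected to be small, a number 0.30 log units higher from compound 1 to compound 4 (within the scatter), and may not rise beyond the scatter. Compound 4 is therefore estimated to give 7.1 in this assay, with a plausible range from 6.4 to 7.8.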

Compound 4, negative logarithm of the antagonist equilibrium constant: 7.1
Beside the measured number, compound 4's estimate shows no gap at the digits printed, within the range that was stated.
By their numbers in this assay, from the lowest: compounds 1, 2 and 4 (each within the scatter of the next); then compound 3.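

Replacing the 5-chloropyrimidin-2-yl group with 5-chloropyridin-2-yl in this assay gives a number 0.30 log units higher from compound 1 to compound 4 (within the scatter), so the two groups cannot be told apart on this amine nitrogen. For the compounds shown here, this is the first pair to differ in one place, and it gives a direct reading at this position: the count of hetero atoms in the ring goes from 2 to 1, as does the count of hydrogen-bond acceptors, without moving the number beyond the scatter. Nothing measured here explains this outcome.

The other steps cannot be read, and the number of compound 3, 8, cannot be tied to any single group, since compound 3 differs from compound 1 and from compound 4 in more than one place. On these data alone, it remains open whether the same tolerance would hold for a pyrazine ring, or for a 5-bromopyridin-2-yl or 5-methoxypyridin-2-yl group on this nitrogen, and whether it would carry over to a different acyl group on the shared core.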